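Acetyl to pyrrolidinyl on a weakly cytotoxic core

The compounds below may be only part of what the source reports. "The series", "measured", "known", "first", "only" and "open" are said of these compounds alone.

The measured values come from a toxicity assay on NIH3T3 cells (Mus musculus) for cytotoxicity, read by resazurin assay; a higher number here means that more compound is needed for the effect, a lower number that less compound is needed:
compound 1, `CC(=O)c1ccc(NCc2cncn2Cc2ccc(-c3ccccc3)cc2)cc1-c1ccccc1`: > 10000 nM, a limit of the assay
compound 2, `COC(=O)c1ccc(NCc2cncn2Cc2ccccc2)cc1-c1ccccc1`: > 1000 nM, a limit of the assay
compound 3, `COC(=O)c1ccc(NCc2cncn2Cc2ccccc2N)cc1-c1ccccc1`: 25000 nM

Compound 1 stands only at a limit in this assay, as the limit of > 10000 nM in this assay, at which 1 of the 3 values shown sits, shows. Compound 2 likewise sits at a limit, (the limit of > 1000 nM in this assay, at which 1 of the 3 values shown sits). Going by the values given here, the only step measured on a single change, a step that the limit leaves unreadable from compound 2 to compound 3, is left without a readable size by the limit of > 1000 nM in this assay, at which 1 of the 3 values shown sits, so the three values together say no more than that all of them are weak in this assay, compound 3 giving a number and the other two only limits.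

Compound 4, `c1ccc(-c2ccc(Cn3cncc3CNc3ccc(N4CCCC4)c(-c4ccccc4)c3)cc2)cc1`, differs from compound 1 by pyrrolidin-1-yl in place of acetyl on an aromatic carbon. Among the compounds with values here, no measured step covers this change, so nothing here points in either direction, and the step that the limit leaves unreadable from compound 1 to compound 4 is expected to stay within the scatter. Compound 4 is therefore estimated at 20000 nM, with an expected range from 5000 nM to 60000 nM, and a fair chance that this assay again reports only a limit.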

Compound 4, half-maximal effective concentration: > 1000 nM
Compound 4: no number, only a limit (the forecaster's own chance of this, stated with the estimate: 50%); the middle value is on the limit's open side.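

Compound 1 and compound 4 both stand only at limits in this assay, so no step can be read for pyrrolidin-1-yl in place of acetyl. The compounds shown leave open whether this change shifts the cytotoxicity at all, and in which direction.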